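Swapping the Ether-Linked Group and Oral Exposure

A few compounds are considered here, and "the series" means these few. Any claim that something is new, unique, unknown or untested is made for them only; others in the source may bear on it.

Of the compounds shown here, three have been measured in an in vivo ADME assay on the whole organism (strain C57BL/cAnNCrl) for pharmacokinetics, with Mus musculus as the target, at a dose of 10 mg/kg by the oral route; on this read-out lower numbers stand for lower exposure and higher numbers for higher exposure at the dose given. Compound 1, `CC(C)(C)c1cc(NC(=O)Nc2cccc(Oc3ccnc4[nH]c(=O)cnc34)c2)n(-c2ccccc2)n1`, gives 29500 nM. Compound 2, `Cc1nc2c(Oc3ccc(NC(=O)Nc4cc(C(F)(F)F)ccc4F)c4ccccc34)ccnc2[nH]c1=O`, gives 33 nM. Compound 3, `Cc1ccc(-n2nc(C(C)(C)C)cc2NC(=O)Nc2ccc(Oc3ccnc4[nH]c(S)nc34)cc2F)cc1`, gives 11700 nM, the second highest of the three numbers; it lies nearest to compound 1, whose number is higher by a gap beyond the usual scatter, and furthest from compound 2, whose number is far lower. Compound 4, `Cc1ccc(-n2nc(C(C)(C)C)cc2NC(=O)Nc2ccc(Oc3ccnc4[nH]c(=O)cnc34)cc2F)cc1`, has not yet been measured. It differs from compound 3 in one place: a group of 11 heavy atoms (7 carbon, 3 nitrogen, 1 oxygen; one six-membered aromatic ring with 1 hetero atom, one six-membered aromatic ring with 2 hetero atoms) in place of a group of 10 heavy atoms (6 carbon, 3 nitrogen, 1 sulfur; one five-membered aromatic ring with 2 hetero atoms, one six-membered aromatic ring with 1 hetero atom), on an oxygen on an aromatic ring. The group that enters is the same one that compound 1 carries on an oxygen on an aromatic ring, and compound 1 has the highest number of the three. Going by the values given here, no measured pair shows this exact exchange, so its size cannot be read directly from the data. A small rise in this assay is expected, a 1.4-fold higher number from compound 3 to compound 4 (0.14 log units; within the scatter), close to the edge of the scatter. Compound 4 is expected to give 16000 nM, within a range from 4000 nM to 50000 nM.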

Compound 4, maximal plasma concentration: 33600 nM
Compound 4: middle estimate off by 2.1-fold (0.32 log units), on the low side, within the range that was stated.
By their numbers in this assay, from the lowest: compound 2; then compound 3; then compounds 1 and 4 (each within the scatter of the next).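

In this assay the exchange of groups on the oxygen on an aromatic ring gives a 2.9-fold higher number from compound 3 to compound 4 (0.46 log units; beyond the scatter) as a modest step, yet one beyond the usual scatter. Going by these compounds alone, this is the first direct reading of a change at this place, and it shows that oral exposure responds to the group there, with the group that has two six-membered aromatic rings doing better than the sulfur-bearing group with a five-membered ring. Nothing measured alongside these numbers explains the rise or ties it to any single feature of the two groups.

Within the data shown here, whether the same exchange would give a similar step on a different core remains open, since this single pair is the only reading. Also open, from the compounds shown here alone, is how a simpler group on that oxygen, such as a pyridine ring carrying an amine, would fare.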